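This account rests on a few compounds, and the source may have more. Where it says the series, first, only, none or still open, it means among the compounds named here.

Measured in a functional assay on MCF7 cells (Homo sapiens) for inhibition, read by MTT assay, with a stated time of 48 h; on this read-out higher numbers stand for weaker inhibition and lower numbers for stronger inhibition:
compound 1 `O=C(CSc1nnc(-c2ccncc2)n1-c1ccccc1)N/N=C/c1ccccc1` — 23600 nM
compound 2 `O=C(CSc1nnc(-c2ccncc2)n1-c1ccccc1)N/N=C/c1ccccc1F` — 22400 nM
compound 3 `O=C(CSc1nnc(-c2ccncc2)n1-c1ccccc1)N/N=C/c1cccc(F)c1` — > 50000 nM, which is a limit of this assay and not a number

Going by the values given here, compound 3 stands at the limit (the limit of > 50000 nM in this assay, at which 1 of the 3 values shown sits); of the three measured compounds it is the only one without a determined number. Compound 1 and compound 2 sit close together, their step of a 1.1-fold lower number from compound 1 to compound 2 (0.02 log units; within the scatter). Against that, an at least 2.1-fold higher number from compound 1 to compound 3 (0.32 log units; beyond the scatter) and an at least 2.2-fold higher number from compound 2 to compound 3 (0.34 log units; beyond the scatter) both run towards weaker inhibition.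

Compound 4 `O=C(CSc1nnc(-c2ccncc2)n1-c1ccccc1)N/N=C/c1ccccc1O` differs from compound 3 in one place: 2-hydroxyphenyl in place of 3-fluorophenyl on a carbon with a double bond to nitrogen. The step moves the substituent back to the position occupied in compound 2, while exchanging fluoro for hydroxyl. Among the compounds with values here, two measured steps bear on it. The step from compound 2 to compound 3, with a 2-fluorophenyl becoming 3-fluorophenyl, pushed the number up to the limit; the reverse change in position is part of the move to compound 4. Within the data shown here, the hydroxyl itself has no precedent here, so its effect cannot be read from the measured values. The expectation for compound 4 is therefore a return towards the range of compound 1 and compound 2, a step of an at least 2.0-fold lower number from compound 3 to compound 4 (0.30 log units; that floor lies within the scatter) in this assay. Compound 4 is estimated at 25000 nM, within 10000 nM to 60000 nM.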

Compound 4, half-maximal inhibitory concentration: 10000 nM
For compound 4 the middle estimate is 2.5-fold (0.40 log units) above the measured one, within the range that was stated.
By their numbers in this assay, from the lowest: compound 4; then compounds 2 and 1 (each within the scatter of the next). At a limit, above all of these: compound 3.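

In this assay, going by these compounds alone, the 2-hydroxyphenyl group on a carbon with a double bond to nitrogen gives the first change that moves towards stronger inhibition beyond the scatter, both against the unsubstituted phenyl (a 2.4-fold lower number from compound 1 to compound 4 (0.37 log units; beyond the scatter)) and against the 2-fluorophenyl (a 2.2-fold lower number from compound 2 to compound 4 (0.35 log units; beyond the scatter)), so compound 4 has the lowest number of the four, whereas fluoro in place of hydrogen at this same place had left the number within the scatter. Compound 3 carries a limit and not a number: the limit of > 50000 nM in this assay, at which 1 of the 4 values shown sits. The change from 3-fluorophenyl to 2-hydroxyphenyl therefore has only a floor (an at least 5.0-fold lower number from compound 3 to compound 4 (0.69 log units; beyond the scatter)), and it alters both the group and where the group sits, so the contribution of each cannot be separated from this step alone.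

The compounds shown leave open whether the hydroxy group keeps its gain as 3-hydroxyphenyl, which would separate the group from its place on the ring. They also leave open whether a 2-aminophenyl or 2-methoxyphenyl group at the same place would match compound 4 or fall back towards compound 1 and compound 2.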